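A few compounds are considered here, and "the series" means these few. Any claim that something is new, unique, unknown or untested is made for them only; others in the source may bear on it.

Measured so far:
compound 1, `O=C(O)CNc1ccc2ccc(C(=O)c3ccc(F)c(O)c3)nc2c1`: in an assay for inhibition of 17-beta-hydroxysteroid dehydrogenase type 1 (Homo sapiens), read by HPLC, with a stated time of 10 min, tested at 1 uM (on this read-out lower numbers stand for less inhibition and higher numbers for more inhibition at the one concentration tested (going by the name of the read-out)), compound 1 gives 3%
compound 2, `Cc1ccc2nc(C(=O)c3ccc(F)c(O)c3)ccc2c1`: in this assay compound 2 gives 12%

Both numbers are small, and the gap between them lies within the usual scatter of repeated measurements, so compound 2 and compound 1 cannot be told apart on these two values; neither shows much inhibition at the single concentration tested.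

Compound 3, `O=C(c1ccc(F)c(O)c1)c1ccc2ccccc2n1`, has not yet been measured. It differs from compound 2 in one place: hydrogen in place of methyl on an aromatic carbon. The methyl that leaves sits on an aromatic carbon of a six-membered aromatic ring of carbon only, part of a fused system of two rings, and nothing replaces it but a hydrogen atom.

Going by the values given here, with no step between measured compounds to go by, and both measured numbers near the bottom of the scale, no step beyond the scatter is expected in this assay in either direction; the step from compound 2 to compound 3 is estimated at a number 4 percentage points lower from compound 2 to compound 3 (within the scatter). Compound 3 is therefore expected to give about 8%, somewhere between 0% and 20%.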

Compound 3, a percentage reported as inhibition, at one concentration (the size of the read-out at that concentration, not a potency) in the 17-beta-hydroxysteroid dehydrogenase type 1 assay: 6%
The estimate for compound 3 lay 2 percentage points above the measured number, within the range that was stated.
By their numbers in the 17-beta-hydroxysteroid dehydrogenase type 1 assay, from the lowest: compounds 1, 3 and 2 (each within the scatter of the next).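

In the 17-beta-hydroxysteroid dehydrogenase type 1 assay, swapping a group on the aromatic carbon for hydrogen does not separate the compounds: the change from methyl gives a number 6 percentage points lower from compound 2 to compound 3 (within the scatter), and the change from (carboxymethyl)amino gives a number 3 percentage points higher from compound 1 to compound 3 (within the scatter). In a physicochemical assay for solubility, in phosphate buffer, with a stated time of 24 h, at pH 7.4, tested at 200 uM (a higher number here means a more soluble compound, a lower number a less soluble compound), compound 2 gives 25000 nM, and hydrogen in place of methyl gives an at least 8.0-fold higher number from compound 2 to compound 3 (0.90 log units; beyond the scatter): the limit of > 200000 nM in the physicochemical assay, at which 1 of the 2 values shown sits. In the physicochemical assay compound 3 gives > 200000 nM, which is a limit of the assay and not a number.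

On these data alone, the full size of the step in the physicochemical assay therefore stays open. Also open, as far as these compounds go, is whether a different group on this aromatic carbon, such as a methoxy group or a chlorine atom, would move inhibition in the 17-beta-hydroxysteroid dehydrogenase type 1 assay beyond the scatter.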